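From compound 3 to compound 4: phenyl for methyl

The compounds below may be only part of what the source reports. "The series", "measured", "known", "first", "only" and "open" are said of these compounds alone.

In a physicochemical assay for solubility, at pH 7 (on this read-out higher numbers stand for higher solubility and lower numbers for lower solubility), compound 1 `CC(=O)N1CCN(C(=O)N2Cc3c(NC(=O)c4ccc(F)cc4)n[nH]c3C2(C)C)CC1` gives > 225000 nM, which is a limit and not a number. Compound 2 `CC1(C)c2[nH]nc(NC(=O)c3ccc(F)cc3)c2CN1C(=O)C1CCN(C2CC2)CC1` gives > 225000 nM, also a limit. Compound 3 `CN1CCN(C(=O)N2Cc3c(NC(=O)c4ccc(F)cc4)n[nH]c3C2(C)C)CC1` gives > 225000 nM, again a limit. The series thus stands at the limit of > 225000 nM in this assay, at which 3 of the 3 values shown sit. Compound 4 `CC1(C)c2[nH]nc(NC(=O)c3ccc(F)cc3)c2CN1C(=O)N1CCN(c2ccccc2)CC1` carries phenyl in place of methyl on an amine nitrogen in a ring. Going by the values given here, two measured steps bear on this change, a step that the two limits leave unreadable from compound 1 to compound 3 and a step that the two limits leave unreadable from compound 2 to compound 3, and neither offers a size. On the structural change alone, a downward move is expected in this assay. The estimated move is an at least 5.6-fold lower number from compound 3 to compound 4 (0.75 log units; beyond the scatter). For compound 4 the expected value is 40000 nM, with an estimated range of 5000 nM to 225000 nM.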

Compound 4, solubility: 55000 nM
Compound 4: the middle estimate sits 1.4-fold (0.14 log units) below what was measured, within the range that was stated.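

In this assay phenyl in place of methyl on this amine nitrogen gives an at least 4.0-fold lower number from compound 3 to compound 4 (0.61 log units; beyond the scatter) and phenyl in place of acetyl at the same place gives an at least 4.0-fold lower number from compound 1 to compound 4 (0.61 log units; beyond the scatter) on the same read-out. Going by these compounds alone, the steps among the earlier compounds cannot be read, so these are the first to show that the group on this nitrogen can move the value. Compound 4 alone gives a number, while the others remain at a limit: the limit of > 225000 nM in this assay, at which 3 of the 4 values shown sit.

Going by these compounds, both steps start from a limit, so their full size stays open. On these data alone, whether a benzyl group or a longer alkyl chain on this nitrogen would match phenyl also stays open.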